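A Methyl to Ethyl Step at the Carbonyl

The source may hold more compounds than are shown below. What is called first, only, known or untested is meant among the compounds shown, and "the series" means these compounds.

In a functional assay on A2780 cells (Homo sapiens) for antiproliferative activity, read by MTT assay, with a stated time of 48 h (a higher number here means a weaker inhibitor of growth, a lower number a stronger inhibitor of growth), compound 1 (`CCOC(=O)N1N=C(c2ccccc2)CC1c1cc(OC)c(OC)c(OC)c1`) gives 6720 nM and compound 2 (`COC(=O)N1N=C(c2ccc(OC)cc2)CC1c1cc(OC)c(OC)c(OC)c1`) gives 5000 nM. These two values lie within the scatter of each other, so compound 2 stands level with compound 1 and the pair sets no order. Compound 3 (`CCOC(=O)N1N=C(c2ccc(OC)cc2)CC1c1cc(OC)c(OC)c(OC)c1`) differs from compound 2 in one place: methyl in place of hydrogen on a saturated chain carbon bound to an oxygen next to a carbonyl group, which turns methoxycarbonyl into ethoxycarbonyl. For the measured compounds named here, no measured pair isolates this change, so no step beyond the scatter is expected in this assay, in either direction. The estimated change is a 1.1-fold higher number from compound 2 to compound 3 (0.04 log units; within the scatter), which is expected to stay within the scatter. For compound 3 the expected value is 5500 nM, with an estimated range from 2500 nM to 11000 nM.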

Compound 3, concentration for 50% growth inhibition: 9270 nM
Compound 3: the middle estimate sits 1.7-fold (0.23 log units) below what was measured; measured number inside the range.
By their numbers in this assay, from the lowest: compounds 2, 1 and 3 (each within the scatter of the next).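

In this assay, for the compounds shown here, the change from methoxycarbonyl to ethoxycarbonyl gives a 1.9-fold higher number from compound 2 to compound 3 (0.27 log units; within the scatter) and so stays within the scatter, the first direct reading of methyl in place of hydrogen on a saturated chain carbon bound to an oxygen next to a carbonyl group. With ethoxycarbonyl held in place, methoxy in place of hydrogen on an aromatic carbon gives a 1.4-fold higher number from compound 1 to compound 3 (0.14 log units; within the scatter) and also stays within the scatter, so neither single change separates these compounds. Nothing available bears on the reason for these values.

On these data alone, whether a longer chain such as butoxycarbonyl or a carboxylic acid at this position would move the number beyond the scatter remains open. Also open, as far as these compounds go, is whether the step from methoxycarbonyl to ethoxycarbonyl would read the same on the core of compound 1.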